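The source may report more compounds than this note shows. Statements on the series, on what has been measured and on what is new or still open speak of the compounds shown alone.

Compound 1 `Cc1ccc2[nH]c(=O)c(CN(Cc3ccc(C(N)=O)cc3)Cc3ccc(C(C)(C)C)cc3)cc2c1` and compound 2 `Cc1ccc2[nH]c(=O)c(CN(Cc3ccc(OCCO)cc3)Cc3ccc(C(C)(C)C)cc3)cc2c1` share one core and differ at a single aromatic carbon, where compound 1 carries carbamoyl and compound 2 carries 2-hydroxyethoxy. In a toxicity assay on MDCK cells (Canis lupus familiaris) for cytotoxicity, read by crystal violet staining, with a stated time of 48 h (a higher number here means that more compound is tolerated, a lower number that less compound is tolerated), compound 1 gives > 5000 nM, which is a limit of the assay and not a number. In this assay compound 2 gives > 5000 nM, also a limit. The step that the two limits leave unreadable from compound 1 to compound 2 is therefore unreadable in size and direction. Where compound 2 stands is known only as a limit, and the one further value shown is a limit as well, namely (the limit of > 5000 nM in this assay, at which 2 of the 2 values shown sit).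

Compound 3 `Cc1ccc2[nH]c(=O)c(CN(Cc3ccc(OC(F)(F)F)cc3)Cc3ccc(C(C)(C)C)cc3)cc2c1` carries the next change: trifluoromethyl in place of 2-hydroxyethyl on an oxygen on an aromatic ring. Among the measured compounds shown here, no measured step bears on this change, since the only step between measured compounds is itself unreadable, so no size of step in this assay can be drawn from the data. The expectation for compound 3 rests solely on compound 2 sitting at its limit > 5000 nM. Compound 3 is expected to show a step that the limit leaves unreadable from compound 2 to compound 3, no step beyond the scatter. Compound 3 is estimated at 8000 nM in this assay, within a range from 3000 nM to 30000 nM, most probably reported again only as a limit.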

Compound 3, half-maximal cytotoxic concentration: > 5000 nM
Compound 3 ended at the assay's limit; the forecaster's own chance of this, stated with the estimate: 70%; the middle value does not contradict the limit.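

In this assay compound 3 gives > 5000 nM, a limit and not a number. No step among compound 1, compound 2 and compound 3 can be read in size or direction: the limit of > 5000 nM in this assay, at which 3 of the 3 values shown sit.

The compounds shown leave open whether carbamoyl, 2-hydroxyethoxy and trifluoromethoxy differ at all in how much compound is tolerated in this assay.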